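Chloro to nitro on the pendant phenyl ring

The compounds below may be only part of what the source reports. "The series", "measured", "known", "first", "only" and "open" are said of these compounds alone.

Of the compounds shown here, two have been measured in a functional assay on DU-145 cells (Homo sapiens) for inhibition, read by MTT assay, with a stated time of 24 h; on this read-out higher numbers stand for weaker inhibition and lower numbers for stronger inhibition. Compound 1 `CCOC(=O)C1=Cc2ccccc2OC1(OCc1cc(-c2ccc3ccccc3c2)no1)C(F)(F)F` gives 71800 nM, while compound 2 `CCOC(=O)C1=Cc2ccccc2OC1(OCc1cc(-c2ccc(Cl)cc2)no1)C(F)(F)F` gives 18200 nM. Within the data shown here, the single measured step, a 3.9-fold lower number from compound 1 to compound 2 (0.60 log units; beyond the scatter), separates them. Among the measured compounds shown here, compound 2 therefore stands with the lower of the two numbers in this assay, and compound 1 is its only neighbour, higher by that step.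

Compound 3 `CCOC(=O)C1=Cc2ccccc2OC1(OCc1cc(-c2ccc([N+](=O)[O-])cc2)no1)C(F)(F)F` differs from compound 2 in one place: nitro in place of chloro on an aromatic carbon. For the measured compounds named here, the one step on record exchanges the whole naphthalen-2-yl group for 4-chlorophenyl on that aromatic carbon, and so bears only loosely on a swap of one substituent on the phenyl ring for another; it shows that changes at this arm have moved the number by a modest amount. Going by the values given here, no measured pair compares two substituents on the phenyl ring directly. The author therefore expects at most a small step in this assay, in no firm direction, and possibly none beyond the scatter. Compound 3 is estimated to give 20000 nM, within a range from 6000 nM to 65000 nM. The step this expectation implies is a 1.1-fold higher number from compound 2 to compound 3 (0.04 log units; within the scatter).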

Compound 3, half-maximal inhibitory concentration: > 150000 nM
Compound 3: a limit, no number; the forecaster's own chance of this, stated with the estimate: 15%; middle value at least 7.5-fold (0.87 log units) from the limit.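

Compound 3 gives no number in this assay, only a limit of the assay: the limit of > 150000 nM in this assay, at which 1 of the 3 values shown sits.

The earlier step had exchanged a whole aryl group, whereas this pair isolates one substituent on the phenyl ring, para to a large group, and nitro in place of chloro gives an at least 8.2-fold higher number from compound 2 to compound 3 (0.91 log units; beyond the scatter), so this single exchange is enough to carry the reading beyond the scatter. Set against the naphthalen-2-yl compound, the new aryl group gives an at least 2.0-fold higher number from compound 1 to compound 3 (0.31 log units; beyond the scatter), which places 4-nitrophenyl on the opposite side of naphthalen-2-yl from 4-chlorophenyl and shows that a phenyl ring at this arm does not by itself fix the reading.

On these data alone, the full size of both new steps stays open, the reading of compound 3 being a limit. Also open, as far as these compounds go, is where a methoxy group, an amine or a bromine atom in the same place, or a phenyl ring with no substituent, would fall in this assay relative to chloro and nitro, since these three compounds cannot show whether chloro is unusual or nitro is.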